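Swapping the aryl on the sulfonyl sulfur: compound 2 to compound 4

The source may hold more compounds than are shown below. What is called first, only, known or untested is meant among the compounds shown, and "the series" means these compounds.

Measured compounds: compound 1 `CN1CCN(c2ccc3[nH]nc(S(=O)(=O)c4ccccc4Cl)c3c2)CC1` with 100%; compound 2 `CN1CCN(c2ccc3[nH]nc(S(=O)(=O)c4cccs4)c3c2)CC1` with 96%; compound 3 `CN1CCN(c2ccc3c(c2)c(S(=O)(=O)c2cccc4ccccc24)nn3Cc2ccccc2)CC1` with 100%.

In a functional assay on HeLa cells for antagonist activity at 5-hydroxytryptamine receptor 6 (Homo sapiens) (a lower number here means a smaller maximal response, a higher number a larger maximal response), compound 2 gives 96%, the lowest of the three numbers, but its steps to compound 1 and to compound 3 are both within the scatter, so the three values are indistinguishable. Compound 4 `COc1cccc(S(=O)(=O)c2n[nH]c3ccc(N4CCN(C)CC4)cc23)c1` has not yet been measured in this assay. It differs from compound 2 in one place: 3-methoxyphenyl in place of thiophen-2-yl on a sulfonyl sulfur. Among the compounds with values here, the only measured step at the same place, a number 4 percentage points lower from compound 1 to compound 2 (within the scatter), lay within the scatter, and no measured change here has moved the maximal response. A step of no more than the scatter is therefore expected, a number 2 percentage points higher from compound 2 to compound 4 (within the scatter). Compound 4 is expected to reach 98%, within 88% to 105%.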

Compound 4, largest response reached (reported as Imax), in percent of the reference or control that the assay uses: 100%
For compound 4 the middle estimate is 2 percentage points below the measured one; the measured number falls inside the stated range.
By their numbers in this assay, from the lowest: compounds 2, 1, 3 and 4 (each within the scatter of the next).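

In this assay, a third aryl group on the sulfonyl sulfur again leaves the maximal response indistinguishable: a number 4 percentage points higher from compound 2 to compound 4 (within the scatter), and no change at the digits printed from compound 1 to compound 4 (within the scatter). This place therefore accepts 3-methoxyphenyl as well as thiophen-2-yl and 2-chlorophenyl, with no readable difference among the three. No available data offer a reason for this flat result.

On these data alone, it remains open whether any group on this sulfonyl sulfur can lower the response, for example a phenyl ring carrying a carboxylic acid or an amine.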